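The source may report more compounds than this note shows. Statements on the series, on what has been measured and on what is new or still open speak of the compounds shown alone.

Compounds measured so far in a functional assay on HT-29 cells (Homo sapiens) for antiproliferative activity, with a stated time of 48 h; a lower number here means a stronger inhibitor, a higher number a weaker inhibitor:

Compound 1, `CCCCC(O)c1cccc(NC(=O)CCCCl)c1`, gives > 100000 nM, which is a limit of this assay and not a number.
Compound 2, `CCCCC(OC)c1cccc(NC(=O)CCCCl)c1`, gives > 100000 nM, likewise a limit.
Compound 3, `C=CC(=O)Nc1cccc(C(O)CCCC)c1`, gives > 100000 nM, again a limit.

The step from compound 1 to compound 2 is methyl in place of hydrogen on an oxygen on a saturated carbon; in this assay it reads a step that the two limits leave unreadable from compound 1 to compound 2, because of the limit of > 100000 nM in this assay, at which 3 of the 3 values shown sit. The cores of compound 1 and compound 3 differ as vinyl in place of 3-chloropropyl on a carbonyl carbon, and that step reads a step that the two limits leave unreadable from compound 1 to compound 3. Among these compounds, each of the three values sits at the same limit, so no ordering among compound 1, compound 2 and compound 3 can be read from them.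

Compound 4, `C=CC(=O)Nc1cccc(C(CCCC)OC)c1`, has not yet been measured in this assay. It differs from compound 3 as methyl in place of hydrogen on an oxygen on a saturated carbon, the same change that leads from compound 1 to compound 2, since the two place descriptions agree word for word. Within the data shown here, the only precedent for this change, from compound 1 to compound 2, is unreadable in size because both ends sit at the limit, and compound 3 itself sits at that limit too.

On that basis compound 4 is expected to remain at or near the limit, with an estimated step that the limit leaves unreadable from compound 3 to compound 4, resting on a step that the two limits leave unreadable from compound 1 to compound 2. That expectation rests also on compound 3 giving > 100000 nM, a limit. The estimate for compound 4 is 150000 nM, expected to fall between 30000 nM and 600000 nM.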

Compound 4, half-maximal inhibitory concentration: 40000 nM
Compound 4: the middle estimate sits 3.8-fold (0.57 log units) above what was measured; measured number inside the range.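

In this assay, on these data alone, methyl in place of hydrogen on an oxygen on a saturated carbon, the hydroxy to methoxy change, gives an at least 2.5-fold lower number from compound 3 to compound 4 (0.39 log units; beyond the scatter), so on the core of compound 3 the change goes with a lower number, and its true size remains unknown. Among these compounds, with the methoxy group kept, vinyl in place of 3-chloropropyl on a carbonyl carbon gives an at least 2.5-fold lower number from compound 2 to compound 4 (0.39 log units; beyond the scatter), so compound 4 is the only compound here with a measured number. This does not show that the change carries from one core to another, since the same change on the core of compound 1 and the other steps among the limited compounds cannot be read, because those values give no size to compare: the limit of > 100000 nM in this assay, at which 3 of the 4 values shown sit.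

The compounds shown leave open whether the methoxy group and the vinyl group each contribute on their own or only together, since only their combination in compound 4 gives a number. They also leave open what an ethoxy group or an amine would do in place of the methoxy group, and what a longer chain would do on the saturated carbon.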